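A few compounds are considered here, and "the series" means these few. Any claim that something is new, unique, unknown or untested is made for them only; others in the source may bear on it.

For the measured compounds named here, compound 2 `COc1ccccc1C(C)Sc1nc2c(cnn2C)c(=O)n1-c1ccccc1` is one of two compounds measured in an assay on isolated protein for inhibition of aldehyde dehydrogenase 1A1 (Homo sapiens) (a higher number here means a weaker inhibitor, a lower number a stronger inhibitor), and compound 2 gives 445 nM. Going by the values given here, its only neighbour is compound 1 `COc1ccc(C(C)Sc2nc3c(cnn3C)c(=O)n2-c2ccccc2)cc1`, which in this assay gives 352 nM. Among the compounds with values here, the step of a 1.3-fold higher number from compound 1 to compound 2 (0.10 log units; within the scatter) is the only measured step, so compound 2 stands at the higher of two numbers that cannot be told apart.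

Compound 3 `CC(Sc1nc2c(cnn2C)c(=O)n1-c1ccccc1)c1cncnc1` differs from compound 2 by pyrimidin-5-yl in place of 2-methoxyphenyl on a saturated chain carbon bound to a saturated chain carbon and a sulfur. Within the data shown here, the one measured step bears on it only loosely: it also exchanged the aryl group on the same saturated chain carbon, and it was a 1.3-fold higher number from compound 1 to compound 2 (0.10 log units; within the scatter), within the scatter. Among the measured compounds shown here, that step swapped two methoxyphenyl groups, whereas compound 3 brings in a ring with two hetero atoms and no methoxy group, a change for which no measured pair exists.

Compound 3 is therefore expected to give a value near that of compound 2, with the step of a 1.5-fold higher number from compound 2 to compound 3 (0.16 log units; within the scatter) carrying wide uncertainty. The estimate for compound 3 is 650 nM, within a range from 220 nM to 2000 nM.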

Compound 3, half-maximal inhibitory concentration: 94 nM
Estimate against measurement, compound 3: 6.9-fold (0.84 log units) above, and the stated range ends above it.
By their numbers in this assay, from the lowest: compound 3; then compounds 1 and 2 (each within the scatter of the next).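

At this saturated chain carbon bound to a saturated chain carbon and a sulfur, the choice of ring does move the number in this assay: pyrimidin-5-yl in place of 2-methoxyphenyl gives a 4.7-fold lower number from compound 2 to compound 3 (0.68 log units; beyond the scatter), and in place of 4-methoxyphenyl it gives a 3.7-fold lower number from compound 1 to compound 3 (0.57 log units; beyond the scatter). Both steps lie beyond the scatter, whereas the earlier exchange of one methoxyphenyl group for the other did not, so this position proves sensitive to a change of ring type, and compound 3 is the strongest inhibitor of the three. No measurement shown here explains this gain.

Each step removes the methoxy group and brings in the ring nitrogens together, so the compounds shown cannot separate these two changes. As far as these compounds go, how an unsubstituted phenyl or a pyridin-3-yl ring would behave on this carbon remains open.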